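A few compounds are considered here, and "the series" means these few. Any claim that something is new, unique, unknown or untested is made for them only; others in the source may bear on it.

Measured compounds:
compound 1 `Cc1ccc(S(=O)(=O)n2cnc3c(Cl)ncnc32)cc1` — 13900 nM
compound 2 `C1=CC(CCNc2ncnc3[nH]cnc23)CCC1` — 40300 nM
compound 3 `Cc1ccc(S(=O)(=O)n2cnc3c(N4CCN(c5ccc(C(F)(F)F)cc5)CC4)ncnc32)cc1` — 42700 nM

In a functional assay on T47D cells (Homo sapiens) for cytotoxicity, read by sulforhodamine B assay, with a stated time of 72 h (a higher number here means a weaker inhibitor, a lower number a stronger inhibitor), compound 1 gives 13900 nM, the lowest of the three numbers. Compound 2 gives 40300 nM and compound 3 gives 42700 nM; both gaps from compound 1 lie beyond the usual scatter, so compound 1 is the strongest inhibitor of the three. No pair among these three differs in only one place, so no single measured step is known in this series.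

Compound 4 `Cc1ccc(S(=O)(=O)n2cnc3c(N4CCC(C)CC4)ncnc32)cc1` has not been measured. It differs from compound 1 by 4-methylpiperidin-1-yl in place of chloro on an aromatic carbon. Within the data shown here, no measured step of this kind is available. Among the measured compounds shown here, the one measured compound that keeps the rest of compound 1 but no longer carries the chloro, compound 3, gives 42700 nM, a weaker result than compound 1. On that basis the step is expected to be a weakening beyond the scatter, in the direction of compound 3: a 2.5-fold higher number from compound 1 to compound 4 (0.40 log units; beyond the scatter). Compound 4 is therefore estimated at 35000 nM in this assay, with a range of 12000 nM to 100000 nM.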

Compound 4, half-maximal inhibitory concentration: 22500 nM
Estimate against measurement, compound 4: 1.6-fold (0.19 log units) above; low and high end bracket the measured number.
By their numbers in this assay, from the lowest: compounds 1, 4, 2 and 3 (each within the scatter of the next, the first and the last beyond it).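

Among these compounds, this is the first single-place step: at the aromatic carbon that carries the chloro in compound 1, this assay gives a 1.6-fold higher number from compound 1 to compound 4 (0.21 log units; within the scatter) for 4-methylpiperidin-1-yl in place of chloro. The position therefore takes a six-membered non-aromatic ring in place of a single chlorine with no change that can be told from the scatter, so the chloro is not required for a reading in this range. Nothing available bears on the reason for this result.

Open, going by these compounds, is whether a morpholine ring, an unsubstituted piperidine or a small open-chain amine such as dimethylamino at this carbon would read the same. Also open is what the 4-methylbenzenesulfonyl group contributes, since no pair shown changes it alone.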